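The source may report more compounds than this note shows. Statements on the series, on what has been measured and on what is new or still open speak of the compounds shown alone.

Compound 1 `Nc1ccccc1NC(=O)c1ccc(COc2ccc(Br)cc2)cc1`: 24400 nM
Compound 2 `CCc1ccc(OCc2ccc(C(=O)Nc3ccccc3N)cc2)cc1`: 6420 nM
Compound 3 `COc1ccc(OCc2ccc(C(=O)Nc3ccccc3N)cc2)cc1`: 5530 nM

Compound 3 stands at the low end of these three numbers in a functional assay on A549 cells (Homo sapiens) for antiproliferative activity, read by CCK-8 assay, with a stated time of 72 h; a higher number here means a weaker inhibitor, a lower number a stronger inhibitor. Its nearest neighbour gives a 1.2-fold lower number from compound 2 to compound 3 (0.06 log units; within the scatter), and its furthest gives a 4.4-fold lower number from compound 1 to compound 3 (0.64 log units; beyond the scatter). Compound 4 `CCCc1ccc(OCc2ccc(C(=O)Nc3ccccc3N)cc2)cc1` differs from compound 3 by propyl in place of methoxy on an aromatic carbon. For the measured compounds named here, the closest precedent is the swap between ethyl and methoxy, a 1.2-fold lower number from compound 2 to compound 3 (0.06 log units; within the scatter), while the swap from bromo to ethyl gave a 3.8-fold lower number from compound 1 to compound 2 (0.58 log units; beyond the scatter). With only these steps to go on, no change beyond the scatter is expected in this assay, perhaps a slight rise. The expected step is a 1.4-fold higher number from compound 3 to compound 4 (0.13 log units; within the scatter). Compound 4 is estimated at 7500 nM, within an expected range of 3500 nM to 16000 nM.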

Compound 4, half-maximal inhibitory concentration: 5210 nM
Compound 4: middle estimate off by 1.4-fold (0.16 log units), on the high side; measured number inside the range.
By their numbers in this assay, from the lowest: compounds 4, 3 and 2 (each within the scatter of the next); then compound 1.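

In this assay, propyl in place of methoxy gives a 1.1-fold lower number from compound 3 to compound 4 (0.03 log units; within the scatter) and the added methyl on the chain gives a 1.2-fold lower number from compound 2 to compound 4 (0.09 log units; within the scatter) so at this position propyl, ethyl and methoxy cannot be told apart. Propyl in place of bromo gives a 4.7-fold lower number from compound 1 to compound 4 (0.67 log units; beyond the scatter) which leaves compound 1 as the only one of the four that stands apart. Whether that gap belongs to bromo alone stays open, as chloro and fluoro are not among the compounds shown. From the compounds shown here alone, it is also open whether a hexyl chain, an amine or a carboxylic acid at this position would stay level with compound 4. No measurement shown here accounts for these results.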